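The compounds below may be only part of what the source reports. "The series", "measured", "known", "first", "only" and "open" are said of these compounds alone.

Working notes on the amide series

Compound 1 `CCC1C(=O)N(C)c2cnc(-n3ccc4cc(C(N)=O)ccc43)nc2N1c1ccn(C)n1` carries a primary carboxamide on the bicyclic substituent and a methylpyrazolyl group on the core nitrogen. In a functional assay on MCF7 cells (Homo sapiens) for antiproliferative activity, read by CCK-8 assay, with a stated time of 72 h (a higher number here means a weaker inhibitor of growth, a lower number a stronger inhibitor of growth), compound 1 is recorded as "not active" (no number reported), so no single number places it on the scale; it stands only as a compound without measurable growth inhibition under these conditions. Two measured neighbours frame the series. Compound 2 `CC[C@@H]1C(=O)N(C)c2cnc(-n3ccc4cc(C(=O)NC(C)C)ccc43)nc2N1C1CCCC1`, with a secondary isopropyl amide and a cyclopentyl group on the core nitrogen, gives 1670 nM in this assay. Compound 3 `CCC1C(=O)N(C)c2cnc(Nc3ccc(S(N)(=O)=O)cc3)nc2N1c1ccn(C)n1` keeps the methylpyrazolyl group of compound 1 but replaces the bicyclic amide by a sulfonamide-bearing anilino group; in this assay compound 3 gives 36600 nM, a far higher value than compound 2 shows.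

Compound 4 `CCCNC(=O)c1ccc2c(ccn2-c2ncc3c(n2)N(c2ccn(C)n2)C(CC)C(=O)N3C)c1` is the next step from compound 1: propyl in place of hydrogen on an amide-type nitrogen. Since compound 1 has no number, the size of the step cannot be computed, but the direction expected is toward measurable activity, as secondary amide compound 2 shows a number where primary amide compound 1 shows none. With the methylpyrazolyl group retained, as in compound 3, only moderate activity is expected.

Compound 4 is estimated at 12000 nM in this assay, within a range of 2500 nM to 60000 nM.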

Compound 4, concentration for 50% growth inhibition: 6420 nM
Compound 4: the middle estimate sits 1.9-fold (0.27 log units) above what was measured; the measured number falls inside the stated range.
By their numbers in this assay, from the lowest: compound 2; then compound 4; then compound 3.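

No new step can be read from compound 1 to compound 4: in this assay compound 4 gives 6420 nM against no number for compound 1 ("not active" (no number reported)). The compounds shown leave open how far propyl in place of the amide hydrogen alone shifts growth inhibition on the shared core. No available evidence bears on this result.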